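The compounds below may be only part of what the source reports. "The series", "measured", "known", "first", "only" and "open" are said of these compounds alone.

Compound 1 `CCCCNc1nc(N)nc(C)c1CCCc1ccccc1`: 749 nM
Compound 2 `CCCCNc1nc(N)nc(C)c1C`: 3280 nM

In an assay on HEK293 cells for agonist activity at Toll-like receptor 8 (Homo sapiens), read by spectrophotometry (on this read-out lower numbers stand for an effect already at smaller amounts and higher numbers for an effect only at larger amounts of compound), compound 2 gives the highest of the two numbers, and compound 1 gives a lower number by a gap beyond the usual scatter. Compound 3 `CCCCNc1nc(N)nc(C)c1CCCC` differs from compound 2 in one place: propyl in place of hydrogen on a saturated chain carbon bound to an aromatic carbon. Among the measured compounds shown here, no measured pair shows this same change, so the step can only be guessed. Because compound 1 gives 749 nM, a modest move toward lower numbers is expected for compound 3. The expected step is a 2.1-fold lower number from compound 2 to compound 3 (0.31 log units; beyond the scatter). Compound 3 is estimated at 1600 nM, within a range from 600 nM to 4500 nM.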

Compound 3, half-maximal effective concentration: 780 nM
Compound 3: middle estimate off by 2.1-fold (0.31 log units), on the high side; the measured number falls inside the stated range.
By their numbers in this assay, from the lowest: compounds 1 and 3 (each within the scatter of the next); then compound 2.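

In this assay, propyl in place of hydrogen on this saturated chain carbon gives a 4.2-fold lower number from compound 2 to compound 3 (0.62 log units; beyond the scatter), so a plain carbon chain without a ring is enough to lower the number. Methyl in place of phenyl at the chain end gives a 1.0-fold higher number from compound 1 to compound 3 (0.02 log units; within the scatter), a step within the scatter, so the phenyl adds nothing measurable here. Nothing measured here explains either step. Still open, on these data alone, is how the number follows chain length, with ethyl or a longer chain such as hexyl. Also open, as far as these compounds go, is what an amine or a carboxylic acid at the chain end would do.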